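Cytotoxicity of Compound 4 Estimated from Its Neighbours

This account rests on a few compounds, and the source may have more. Where it says the series, first, only, none or still open, it means among the compounds named here.

In an ADME assay on L02 cells (Homo sapiens) for cytotoxicity, read by MTT assay, with a stated time of 48 h (on this read-out lower numbers stand for stronger inhibition and higher numbers for weaker inhibition), compound 2 `CC(=O)OC[C@H]1CN(c2ccc(-n3cc(-c4ccccn4)cn3)c(F)c2)C(=O)O1` gives only a limit of the assay, > 400 ug/mL. Compound 1 `O=C1O[C@@H](CN2CCCCC2)CN1c1ccc(-n2cc(-c3ccccn3)cn2)c(F)c1` likewise reaches only a limit, > 400 ug/mL. Compound 3 `O=C1O[C@@H](Cn2ccnn2)CN1c1ccc(-n2cc(-c3ccccn3)cn2)c(F)c1` gives a number, 49 ug/mL, so that an at least 8.1-fold lower number from compound 2 to compound 3 (0.91 log units; beyond the scatter) and an at least 8.1-fold lower number from compound 1 to compound 3 (0.91 log units; beyond the scatter), whereas a step that the two limits leave unreadable from compound 1 to compound 2. Compound 2 thus sits with compound 1 at the limit of > 400 ug/mL in this assay, at which 2 of the 3 values shown sit. Compound 4 `CNC(=O)[C@H]1CN(c2ccc(-n3cc(-c4ccccn4)cn3)c(F)c2)C(=O)O1` differs from compound 2 by methylcarbamoyl in place of acetoxymethyl on a saturated ring carbon. Among the measured compounds shown here, no measured step exchanges acetoxymethyl for methylcarbamoyl; the readable steps all introduce 1H-1,2,3-triazol-1-yl, so they bear on this change only loosely. The expectation is therefore a number no higher from compound 2 to compound 4 (the limit leaves the size open), with the result most likely remaining a limit. The estimate for compound 4 is 400 ug/mL, with a range from 150 ug/mL to 900 ug/mL.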

Compound 4, half-maximal inhibitory concentration: 217 ug/mL
Compound 4: middle estimate off by 1.8-fold (0.27 log units), on the high side; low and high end bracket the measured number.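

In this assay compound 4 gives 217 ug/mL, so methylcarbamoyl on this saturated ring carbon yields a number. Acetoxymethyl and (piperidin-1-yl)methyl yield only limits of the assay, with an at least 1.8-fold lower number from compound 2 to compound 4 (0.26 log units; that floor lies within the scatter) and an at least 1.8-fold lower number from compound 1 to compound 4 (0.26 log units; that floor lies within the scatter). Neither floor clears the scatter, so neither step establishes a real drop. Against (1H-1,2,3-triazol-1-yl)methyl, the only earlier group with a number, the change gives a 4.4-fold higher number from compound 3 to compound 4 (0.65 log units; beyond the scatter), so the number at this position clearly differs between these two groups.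

The compounds shown leave open how large the steps from the two limits truly are. They also leave open how a carboxylic acid or a primary amine on this saturated ring carbon would read in this assay.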